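Cyclobutyl for 4-hydroxycyclohexyl on the amine of compound 2

The source may hold more compounds than are shown below. What is called first, only, known or untested is meant among the compounds shown, and "the series" means these compounds.

Series notes. Compound 1 `OC1CCC(Nc2nc(-c3ccccc3)nc3c2nnn3Cc2ccccc2F)CC1` and compound 2 `OC1CCC(Nc2nc(-c3ccccc3)nc3c2nnn3Cc2ccccc2)CC1` share one core and differ at one point; compound 3 `c1ccc(Cn2nnc3c(NC4CCC4)nc(-c4ccccc4)nc32)cc1` is the next member. In an assay on isolated protein for binding affinity to adenosine receptor A1 (Bos taurus) (on this read-out lower numbers stand for stronger inhibition and higher numbers for weaker inhibition), compound 1 gives 1850000 nM and compound 2 gives 2700000 nM. Among the measured compounds shown here, the one measured step, a 1.5-fold higher number from compound 1 to compound 2 (0.16 log units; within the scatter), is within the scatter, so compound 2 holds the higher of the two numbers only nominally. The change to compound 3 is cyclobutyl in place of 4-hydroxycyclohexyl on a nitrogen on an aromatic ring. For the measured compounds named here, no measured step touches this part of the core: the step from compound 1 to compound 2 lies on the benzyl ring and says nothing about the amine substituent. There is therefore no ground for expecting a shift beyond the scatter in this assay, and the expected step of a 1.4-fold lower number from compound 2 to compound 3 (0.13 log units; within the scatter) is set near zero with a wide range. Compound 3 is estimated at 2000000 nM, between 300000 nM and 15000000 nM.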

Compound 3, inhibition constant: 5000000 nM
Compound 3: middle estimate off by 2.5-fold (0.40 log units), on the low side, and the stated range covers the measured number.
By their numbers in this assay, from the lowest: compounds 1, 2 and 3 (each within the scatter of the next, the first and the last beyond it).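

Working notes on the amine substituent: in this assay the first measured step at this place, a 1.9-fold higher number from compound 2 to compound 3 (0.27 log units; within the scatter), lies within the scatter, so compound 3 cannot be told apart from compound 2 on this read-out. For this one pair, exchanging 4-hydroxycyclohexyl, with its hydrogen-bond donor and acceptor, for cyclobutyl, which has neither, gives no step beyond the scatter. No available evidence bears on the reason for this result.

Plain cyclohexyl, which would separate the ring size from the hydroxy group, and 4-aminocyclohexyl or a longer chain such as n-butyl on this nitrogen leave open whether any group here moves the number beyond the scatter. Also open, on these data alone, is whether the cyclobutyl step reads the same when the benzyl ring carries the fluoro group of compound 1.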